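The source may hold more compounds than are shown below. What is called first, only, known or untested is meant among the compounds shown, and "the series" means these compounds.

Among the three compounds measured in an assay on a protein complex for inhibition of integrin alpha-5/beta-1 (Homo sapiens), read by ELISA (a lower number here means a stronger inhibitor, a higher number a weaker inhibitor), compound 3 `Cc1cc(C)c(S(=O)(=O)N[C@@H](CNC(=O)CO[C@@H]2C[C@@H](CNc3ccccn3)N(C(=O)CCc3ccccc3)C2)C(=O)O)c(C)c1` gives the highest number, at 25 nM. Compound 1 `Cc1cc(C)c(S(=O)(=O)N[C@@H](CNC(=O)CO[C@@H]2C[C@@H](CNc3ccccn3)N(C(=O)CC(C)(C)C)C2)C(=O)O)c(C)c1` gives 6 nM, and compound 2 `Cc1cc(C)c(S(=O)(=O)N[C@@H](CNC(=O)CO[C@@H]2C[C@@H](CNc3ccccn3)N(C(=O)OCc3ccccc3)C2)C(=O)O)c(C)c1` gives 3.7 nM. The two steps that reach compound 3 both alter the group on the ring amine nitrogen: a 4.2-fold higher number from compound 1 to compound 3 (0.62 log units; beyond the scatter), and a 6.8-fold higher number from compound 2 to compound 3 (0.83 log units; beyond the scatter). The change from compound 1 to compound 2, by contrast, is small: a 1.6-fold lower number from compound 1 to compound 2 (0.21 log units; within the scatter).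

Compound 4 `Cc1cc(C)c(S(=O)(=O)N[C@@H](CNC(=O)CO[C@H]2CN[C@H](CNc3ccccn3)C2)C(=O)O)c(C)c1` goes further than either of these steps. Here the whole group is removed: hydrogen in place of phenethylcarbonyl on an amine nitrogen in a ring. For the measured compounds named here, no measured compound carries a bare amine nitrogen in this ring, so no step in the set bears directly on this change. What the set does show is that the number in this assay moves with the group on that nitrogen, and that compound 3 holds the least favourable of the three. Whether stripping the group away recovers the lower numbers of compound 1 and compound 2, or weakens inhibition further, cannot be read from these three alone, and the expectation is therefore broad. Compound 4 is expected to give about 50 nM in this assay, within a range of 10 nM to 250 nM, which would mean an estimated step of a 2.0-fold higher number from compound 3 to compound 4 (0.30 log units; within the scatter).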

Compound 4, half-maximal inhibitory concentration: 286 nM
For compound 4 the middle estimate is 5.7-fold (0.76 log units) below the measured one; measured number outside the range, above it.
By their numbers in this assay, from the lowest: compounds 2 and 1 (each within the scatter of the next); then compound 3; then compound 4.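

Removing the group from the amine nitrogen in the ring costs far more in this assay than exchanging one group for another: an 11-fold higher number from compound 3 to compound 4 (1.06 log units; beyond the scatter). Even phenethylcarbonyl, which had given the highest number of the three substituted compounds, is thus much better than hydrogen at this position, and the loss is larger still against the other two groups, with a 77-fold higher number from compound 2 to compound 4 (1.89 log units; beyond the scatter) and a 48-fold higher number from compound 1 to compound 4 (1.68 log units; beyond the scatter). The largest difference among the substituted compounds, a 6.8-fold higher number from compound 2 to compound 3 (0.83 log units; beyond the scatter), is smaller than any of these steps, so across these four compounds the presence of a group on this nitrogen matters more than the choice among neopentylcarbonyl, benzyloxycarbonyl and phenethylcarbonyl.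

Nothing available explains the loss seen with the unsubstituted amine nitrogen. From the compounds shown here alone, it also remains open how much of the group is needed, since an acetyl group would test whether a carbonyl with a single methyl is enough to recover the lower numbers, and a benzyl group attached directly to the nitrogen would test whether the carbonyl is needed at all.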